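Removing the chloro from an alpha-1 antagonist

The source may hold more compounds than are shown below. What is called first, only, known or untested is meant among the compounds shown, and "the series" means these compounds.

Three compounds have been measured:
compound 1 `COc1ccc(N2CCN(CCNC(=O)c3cccnc3)CC2)cc1` 1620 nM
compound 2 `COc1ccc(Cl)cc1N1CCN(CCNC(=O)c2cc3ccccc3oc2=O)CC1` 49 nM
compound 3 `Cc1ccc(N2CCN(CCNC(=O)c3cccnc3)CC2)cc1` 295 nM

In a functional assay for antagonist activity at Adrenergic receptor alpha-1 (Rattus norvegicus) (on this read-out higher numbers stand for weaker binding and lower numbers for tighter binding), compound 2 gives the lowest number of the three; compound 3 comes nearest, and compound 1 lies furthest away. Among the compounds with values here, the only single step among them, a 5.5-fold lower number from compound 1 to compound 3 (0.74 log units; beyond the scatter), concerns the substituent on the aryl ring, not the site changed here. Compound 4 `COc1ccccc1N1CCN(CCNC(=O)c2cc3ccccc3oc2=O)CC1` differs from compound 2 by hydrogen in place of chloro on an aromatic carbon. Within the data shown here, no measured step bears on losing a chloro at this place, so the expectation rests on the general weight of compound 2's value 49 nM alone. Compound 4 is expected to give a somewhat higher number, a 2.4-fold higher number from compound 2 to compound 4 (0.39 log units; beyond the scatter), and is estimated at 120 nM, with a range from 40 nM to 400 nM.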

Compound 4, dissociation constant: 19.5 nM
Compound 4: middle estimate off by 6.2-fold (0.79 log units), on the high side; the measured number lies below the stated range.
By their numbers in this assay, from the lowest: compound 4; then compound 2; then compound 3; then compound 1.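

In this assay the chloro of the 5-chloro-2-methoxyphenyl group proves unnecessary for a low number: hydrogen in its place gives a 2.5-fold lower number from compound 2 to compound 4 (0.40 log units; beyond the scatter), the first step read at this place. On this ring, losing the chloro para to the methoxy group lowers the number rather than raising it. No measurement at hand accounts for the direction of this step. As far as these compounds go, whether fluoro, bromo or an amine at the same place would also give a lower number than chloro stays open. So does whether the step carries over to the core of compound 1 .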